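This account rests on a few compounds, and the source may have more. Where it says the series, first, only, none or still open, it means among the compounds named here.

Measured compounds:
Compound 1, `O=C(Nc1ccc(Oc2ccnc3[nH]ccc23)cc1)c1cc(-c2ccc(C(F)(F)F)cc2)ccn1`: 3950 nM
Compound 2, `O=C(Nc1ccc(Oc2ccnc3[nH]ccc23)cc1)c1cc(-c2ccc(Cl)cc2)ccn1`: 4310 nM
Compound 3, `O=C(Nc1ccc(Oc2ccnc3[nH]ccc23)c(F)c1)c1ccc(-c2ccccc2)cn1`: 1250 nM

These three share a common core and differ in their outer groups. In a functional assay on A549 cells (Homo sapiens) for cytotoxicity, read by MTT assay, with a stated time of 72 h (on this read-out higher numbers stand for weaker inhibition and lower numbers for stronger inhibition), compound 3 gives the lowest number of the three, and its gaps to compound 1 and to compound 2 both lie beyond the usual scatter, so compound 3 is the most potent of the measured set. Compound 4, `O=C(Nc1ccc(Oc2ccnc3[nH]ccc23)c(F)c1)c1ccc(-c2ccc(F)cc2F)cn1`, has not yet been measured. It differs from compound 3 in one place: 2,4-difluorophenyl in place of phenyl on an aromatic carbon. For the measured compounds named here, only one measured step speaks to a change of this kind, a 1.1-fold higher number from compound 1 to compound 2 (0.04 log units; within the scatter), which exchanges one small substituent for another on the same outer ring and stays within the scatter. That step is not a direct match. Compound 4 adds fluorine to a ring that carries none in compound 3 rather than swapping one group for another, and nothing measured here shows the effect of fluorine on that ring. The expectation is therefore a step of about a 1.1-fold lower number from compound 3 to compound 4 (0.06 log units; within the scatter) in this assay, that is no change beyond the scatter. Compound 4 is expected to give 1100 nM, with a range from 450 nM to 2700 nM.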

Compound 4, half-maximal inhibitory concentration: 3100 nM
Compound 4: the middle estimate sits 2.8-fold (0.45 log units) below what was measured; measured number above the stated range.
By their numbers in this assay, from the lowest: compound 3; then compounds 4, 1 and 2 (each within the scatter of the next).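

In this assay, 2,4-difluorophenyl in place of phenyl gives a 2.5-fold higher number from compound 3 to compound 4 (0.39 log units; beyond the scatter), so the outer ring of compound 3, on an aromatic carbon two atoms from the ring nitrogen and para to a large group, does respond to substitution. For the compounds shown here, the only earlier step between two substituted outer rings, chloro in place of trifluoromethyl, gave a 1.1-fold higher number from compound 1 to compound 2 (0.04 log units; within the scatter), which stayed within the scatter, so the earlier compounds showed no change on an outer ring that could be told apart from noise; this step is modest but goes beyond it, and in the direction of weaker inhibition. Nothing shown here gives a measured reason for the step.

Both fluorines arrive together in compound 4, so the compounds shown cannot say whether one fluorine alone would produce the same step or whether both are needed. Also open, going by these compounds, is how that ring would respond to a different kind of group, such as an amine, a carboxylic acid or a methoxy group, and whether any such group could bring the number lower than that of compound 3 at 1250 nM.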